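This account rests on a few compounds, and the source may have more. Where it says the series, first, only, none or still open, it means among the compounds named here.

Compound 1 `CCC(=O)N1CC2CC(C1)N2`, compound 2 `O=C(C1CCC1)N1CC2CC(C1)N2` and compound 3 `O=C(C1CCCC1)N1CC2CC(C1)N2` share one core and differ only in the group on the carbonyl carbon. In an assay on SH-EP1 cells for displacement of a labelled ligand from Neuronal acetylcholine receptor; alpha4/beta2 (Homo sapiens), read by scintillation counting (a higher number here means a weaker inhibitor, a lower number a stronger inhibitor), compound 1 gives 6 nM, compound 2 gives 16 nM and compound 3 gives 160 nM. Compound 2 thus stands second highest of the three numbers, closer to compound 1 and a long way from compound 3. Going by the values given here, the one step measured in one place, a 2.7-fold higher number from compound 1 to compound 2 (0.43 log units; beyond the scatter), is modest and runs toward weaker binding as the ring replaces the chain; the values of compound 2 and compound 3 show a much larger gap in the same direction as the ring grows.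

Compound 4 `O=C([C@H]1C[C@@H]1F)N1CC2CC(C1)N2` takes the change (2-fluorocyclopropyl in place of cyclobutyl on a carbonyl carbon). Compound 2 and compound 4 are not directly compared by any measured step, but the smaller ring carries compound 4 back toward the size of compound 1. The step from compound 2 to compound 4 in this assay is therefore expected to be small and toward a lower number, a 1.8-fold lower number from compound 2 to compound 4 (0.25 log units; within the scatter). For compound 4 the estimate in this assay is 9 nM, with a range from 3 nM to 30 nM.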

Compound 4, inhibition constant: 5.4 nM
Estimate against measurement, compound 4: 1.7-fold (0.22 log units) above; measured number inside the range.
By their numbers in this assay, from the lowest: compounds 4 and 1 (each within the scatter of the next); then compound 2; then compound 3.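

In this assay, going by these compounds alone, the earlier compounds showed the number only rising as the group on the carbonyl carbon changed from ethyl to larger rings, whereas the 2-fluorocyclopropyl group reverses that direction (a 3.0-fold lower number from compound 2 to compound 4 (0.47 log units; beyond the scatter)). It also leaves the number level with the open chain (a 1.1-fold lower number from compound 1 to compound 4 (0.05 log units; within the scatter)), so a ring at this position does not in itself mean weaker binding among these compounds, and since cyclobutyl and 2-fluorocyclopropyl have the same count of heavy atoms, that count alone does not set the number. Nothing given here accounts for this result.

The compounds shown do not separate the part played by the fluorine from that of the three-membered ring, which a plain cyclopropyl group would address. Also open, going by these compounds, is how the other stereoisomers of the 2-fluorocyclopropyl group, or a 2-methylcyclopropyl group, would behave at this position.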